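This account rests on a few compounds, and the source may have more. Where it says the series, first, only, none or still open, it means among the compounds named here.

Of the compounds shown here, three on a shared core have been read so far in an in vitro ADME assay on microsomes from liver (Homo sapiens) for metabolic stability, with a stated time of 60 min, tested at 1 uM; on this read-out lower numbers stand for slow clearance and higher numbers for fast clearance. Among the measured compounds shown here, compound 1 `COc1cc(-c2cc(-c3ccc(S(C)(=O)=O)cc3)cnc2N)ccc1O` gives 17 mL.min-1.g-1, the only true number in the set. Compound 2 `COc1ccc(-c2cc(-c3ccc(S(C)(=O)=O)cc3)cnc2N)cn1` stands only as a limit, < 28 mL.min-1.g-1, so its place on the scale is not fixed. Compound 3 `CS(=O)(=O)c1ccc(-c2cnc(N)c(-c3ccc(C(F)(F)F)cc3)c2)cc1` is also a limit, < 7 mL.min-1.g-1.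

The next step leads from compound 2 to compound 4 `CS(=O)(=O)c1ccc(-c2cnc(N)c(-c3ccc(C#N)cc3)c2)cc1`, with 4-cyanophenyl in place of 6-methoxypyridin-3-yl on an aromatic carbon, ortho to an amino group: 4-cyanophenyl in place of 6-methoxypyridin-3-yl on an aromatic carbon. For the measured compounds named here, no measured pair isolates this change, so any expectation rests on few data. The closest guide is compound 3, which also holds a six-membered aromatic ring of carbon only in that place and reads < 7 mL.min-1.g-1, a limit. On that basis, compound 4 is expected to sit toward slow clearance in this assay. The expected change is a step that the limit leaves unreadable from compound 2 to compound 4, a modest move toward slower clearance with an uncertain size, since the starting point is a limit. For compound 4 the estimated clearance is 9 mL.min-1.g-1, with an expected range from 4 mL.min-1.g-1 to 25 mL.min-1.g-1, and the result may well be reported only as a limit.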

Compound 4, intrinsic clearance in microsomes in the Homo sapiens assay: < 5 mL.min-1.g-1
Compound 4: no number, only a limit; the forecaster's own chance of this, stated with the estimate: 55%; middle value at least 1.8-fold (0.25 log units) away from the limit.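

In the Homo sapiens assay compound 2 reads < 28 mL.min-1.g-1 as a limit. In the Homo sapiens assay compound 3 reads < 7 mL.min-1.g-1 as a limit. In the Homo sapiens assay compound 4 reads < 5 mL.min-1.g-1 as a limit. All three compounds stand only as limits, so neither the step from compound 2 to compound 4 nor the step from compound 3 to compound 4 can be read. The compounds shown leave open whether intrinsic clearance truly differs among these three compounds, and by how much. In a physicochemical assay for solubility, read by nephelometry, in phosphate buffer, measured as kinetic solubility, with a stated time of 30 min, at pH 6.5 (a higher number here means a more soluble compound, a lower number a less soluble compound), compound 2 gives 121 ug/mL and compound 4 gives 1.6 ug/mL as measured numbers. In the physicochemical assay the data show a 76-fold lower number from compound 2 to compound 4 (1.88 log units; beyond the scatter) with 4-cyanophenyl in place of 6-methoxypyridin-3-yl on an aromatic carbon.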